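Hydroxy on the aryl ring of a diketo ester series

The compounds below may be only part of what the source reports. "The series", "measured", "known", "first", "only" and "open" are said of these compounds alone.

Compound 1: `C/C=C/n1cc(/C=C/C(=O)CC(=O)C(=O)OCC)c2ccccc21` — > 40 uM
Compound 2: `CCOC(=O)C(=O)CC(=O)/C=C/c1cn(-c2ccccc2)c2ccccc12` — > 40 uM

Of the compounds shown here, two have been measured in an assay on isolated protein for inhibition of DNA nucleotidylexotransferase (Homo sapiens), read by scintillation counting, with a stated time of 10 min; on this read-out lower numbers stand for stronger inhibition and higher numbers for weaker inhibition. Compound 1 `C/C=C/n1cc(/C=C/C(=O)CC(=O)C(=O)OCC)c2ccccc21` gives only a limit of the assay, > 40 uM. Compound 2 `CCOC(=O)C(=O)CC(=O)/C=C/c1cn(-c2ccccc2)c2ccccc12` likewise gives only a limit, > 40 uM. The step that the two limits leave unreadable from compound 1 to compound 2 cannot be read, since both values sit at the limit of > 40 uM in this assay, at which 2 of the 2 values shown sit. Compound 2 thus stands at the limit with no number of its own.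

Compound 3 `CCOC(=O)C(=O)CC(=O)/C=C/c1cn(-c2ccc(O)cc2)c2ccccc12` differs from compound 2 by hydroxy in place of hydrogen on an aromatic carbon. Within the data shown here, no measured step bears on this change, and the single step known, from compound 1 to compound 2, is itself unreadable. Nothing among the shown values points in either direction, so a step beyond the scatter is not expected in this assay, and another limit is the likelier outcome. For compound 3 a value of 60 uM is estimated, within 15 uM to 250 uM, meaning an expected step that the limit leaves unreadable from compound 2 to compound 3.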

Compound 3, concentration for 50% inhibition: > 40 uM
Compound 3: only a limit was reported (the forecaster's own chance of this, stated with the estimate: 70%); the middle value lies beyond the limit too.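

No new step can be read from compound 1, compound 2 and compound 3 in this assay, because all three values are limits: the limit of > 40 uM in this assay, at which 3 of the 3 values shown sit.

As far as these compounds go, whether 4-hydroxyphenyl in place of phenyl changes inhibition at all, and in which direction, stays open.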